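The source may hold more compounds than are shown below. What is called first, only, known or untested is meant among the compounds shown, and "the series" means these compounds.

Measured compounds:
- compound 1 `COc1ccc(-c2cc(N)c(C(=O)c3cc(OC)c(OC)c(OC)c3)s2)cc1OC`: 72 nM
- compound 2 `COc1cc(C(=O)c2sc(-c3ccc(F)cc3)cc2N)cc(OC)c1OC`: 16 nM
- compound 3 `COc1ccc(-c2cc(N)c(C(=O)c3cc(OC)c(OC)c(OC)c3)s2)cc1`: 31 nM

In a functional assay on FM3A cells (Mus musculus) for antiproliferative activity (a higher number here means a weaker inhibitor, a lower number a stronger inhibitor), compound 1 gives the highest of the three numbers. The nearest is compound 3 with a 2.3-fold lower number from compound 1 to compound 3 (0.37 log units; beyond the scatter); the furthest is compound 2 with a 4.5-fold lower number from compound 1 to compound 2 (0.65 log units; beyond the scatter). Compounds 2 and 3 are within the scatter of each other (a 1.9-fold higher number from compound 2 to compound 3 (0.29 log units; within the scatter)).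

Compound 4 `CCOc1ccc(-c2cc(N)c(C(=O)c3cc(OC)c(OC)c(OC)c3)s2)cc1` is not yet measured. It differs from compound 1 as follows: 4-ethoxyphenyl in place of 3,4-dimethoxyphenyl on an aromatic carbon. The step that bears most on it is the change from compound 1 to compound 3, which also removes one methoxy and gave a 2.3-fold lower number from compound 1 to compound 3 (0.37 log units; beyond the scatter). Compound 4 keeps one alkoxy on the same ring, so a lower number than compound 1 is expected in this assay, of a size near that step: a 2.1-fold lower number from compound 1 to compound 4 (0.31 log units; beyond the scatter). For compound 4 the estimate is 35 nM, with a range from 12 nM to 100 nM.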

Compound 4, half-maximal inhibitory concentration: 510 nM
Estimate against measurement, compound 4: 15-fold (1.16 log units) below; the whole stated range lies below it.
By their numbers in this assay, from the lowest: compounds 2 and 3 (each within the scatter of the next); then compound 1; then compound 4.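

In this assay, this position tolerates little growth at the alkoxy chain: methyl in place of hydrogen on the chain, turning methoxy into ethoxy, gives a 16-fold higher number from compound 3 to compound 4 (1.22 log units; beyond the scatter). The 4-ethoxyphenyl group also compares poorly with 3,4-dimethoxyphenyl, a 7.1-fold higher number from compound 1 to compound 4 (0.85 log units; beyond the scatter), and with 4-fluorophenyl, a 32-fold higher number from compound 2 to compound 4 (1.50 log units; beyond the scatter), so losing a methoxy does not by itself lower the number. No available evidence accounts for this sharp rise. Open, as far as these compounds go, is whether a propoxy chain raises the number further, and how a hydroxy or methyl group at this position compares.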